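This account rests on a few compounds, and the source may have more. Where it says the series, first, only, none or still open, it means among the compounds named here.

In a functional assay on HL-60 cells (Homo sapiens) for cytotoxicity, read by WST assay, with a stated time of 48 h (a higher number here means that more compound is needed for the effect, a lower number that less compound is needed), compound 1 `Cc1cccc(C[C@H]2C(=O)OC[C@@H]2Cc2ccccc2)c1` gives 53000 nM and compound 2 `O=C1OC[C@H](Cc2ccccc2)[C@H]1Cc1cccc(Cl)c1` gives 36000 nM, so compound 2 stands level with compound 1 within the scatter. Compound 3 `O=C1OC[C@H](Cc2ccccc2)[C@H]1Cc1ccc(Cl)c(Cl)c1` keeps the structure of compound 2 but has chloro in place of hydrogen on an aromatic carbon. Within the data shown here, the only measured step bearing on this, chloro in place of methyl on an aromatic carbon, is small: a 1.5-fold lower number from compound 1 to compound 2 (0.17 log units; within the scatter). In this assay a similarly small step is therefore expected, a 1.3-fold lower number from compound 2 to compound 3 (0.11 log units; within the scatter), with no clear shift beyond the scatter. For compound 3 the estimated value is 28000 nM, with an expected range from 11000 nM to 65000 nM.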

Compound 3, half-maximal effective concentration: 19000 nM
Compound 3: middle estimate off by 1.5-fold (0.17 log units), on the high side; low and high end bracket the measured number.
By their numbers in this assay, from the lowest: compounds 3, 2 and 1 (each within the scatter of the next, the first and the last beyond it).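

In this assay the step is a 1.9-fold lower number from compound 2 to compound 3 (0.28 log units; within the scatter), so a chloro group can be added ortho to the existing chloro group and para to a large group without a shift beyond the scatter. The earlier step only exchanged one group for another at a single ring position, whereas this one fills a new ring position. Nothing available explains this result.

Still open, as far as these compounds go, is whether an amine or a carboxylic acid at this position would move the number beyond the scatter. Also open, from the compounds shown here alone, is how chloro here would behave without the first chloro group.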